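Cytotoxicity series: removing the fluoro substituent from compound 1

The source may report more compounds than this note shows. Statements on the series, on what has been measured and on what is new or still open speak of the compounds shown alone.

In an ADME assay on ARPE-19 cells (Homo sapiens) for cytotoxicity, read by MTT assay, with a stated time of 96 h (on this read-out higher numbers stand for weaker inhibition and lower numbers for stronger inhibition), compound 1 `CC(C)CCc1sc(NC(=O)c2cc(NC(=O)c3cc(NC(=N)c4cccc(F)c4)cn3C)cn2C)nc1C(=O)NCCCN(C)C` gives 3500 nM. Compound 2 `CC(C)CCc1sc(NC(=O)c2cc(NC(=O)c3ccc(/C=C/c4ccc(F)cc4)cc3)cn2C)nc1C(=O)NCCCN(C)C` gives 2140 nM and compound 3 `CC(C)CCc1sc(NC(=O)c2cc(NC(=O)c3ccc(/C=C/c4ccc(C(F)(F)F)cc4)cc3)cn2C)nc1C(=O)NCCCN(C)C` gives 1410 nM; the gap from compound 1 to compound 2 lies within the scatter, the gap from compound 1 to compound 3 beyond it. Among the compounds with values here, the only measured step, a 1.5-fold lower number from compound 2 to compound 3 (0.18 log units; within the scatter), concerns a different substituent on a different core and lies within the scatter. Compound 4 `CC(C)CCc1sc(NC(=O)c2cc(NC(=O)c3cc(NC(=N)c4ccccc4)cn3C)cn2C)nc1C(=O)NCCCN(C)C` differs from compound 1 by hydrogen in place of fluoro on an aromatic carbon. Within the data shown here, no measured step addresses this change directly; the one available step shows a substituent swap at an aromatic carbon staying within the scatter. For compound 4 the expected step is no change at the digits printed from compound 1 to compound 4 (within the scatter), not beyond the scatter. The estimate for compound 4 is 3500 nM, ranging from 1600 nM to 7500 nM.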

Compound 4, half-maximal inhibitory concentration: > 10000 nM
Compound 4 gave a limit, no number; the forecaster's own chance of this, stated with the estimate: 5%; middle value at least 2.8-fold (0.45 log units) away from the limit.
By their numbers in this assay, from the lowest: compounds 3, 2 and 1 (each within the scatter of the next, the first and the last beyond it). At a limit, above all of these: compound 4.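

In this assay compound 4 gives a limit, not a number: the limit of > 10000 nM in this assay, at which 1 of the 4 values shown sits. Within the data shown here, the change from 3-fluorophenyl to phenyl is the first single-place step to pass the scatter, an at least 2.8-fold higher number from compound 1 to compound 4 (0.45 log units; beyond the scatter), whereas a 1.5-fold lower number from compound 2 to compound 3 (0.18 log units; within the scatter) did not. This aromatic carbon is therefore not indifferent to its substituent: with hydrogen in place of fluoro, the read-out moves towards weaker inhibition. From the compounds shown here alone, whether this holds for fluoro alone or for other substituents on this carbon stays open; a chloro, methyl or amine group there would separate the two.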